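This account rests on a few compounds, and the source may have more. Where it says the series, first, only, none or still open, it means among the compounds named here.

Measured compounds:
- compound 1 `C=C(C)C(=O)N1N=C(c2ccc(-n3ccnc3)cc2)CC1c1ccc(N(C)C)cc1` gives 4.3% in a functional assay on MDA-MB-231 cells (Homo sapiens) for inhibition, read by sulforhodamine B assay, tested at 10 uM; on this read-out lower numbers stand for less inhibition and higher numbers for more inhibition at the one concentration tested (going by the name of the read-out)
- compound 2 `COC(=O)CC(=O)N1N=C(c2ccc(-n3ccnc3)cc2)CC1c1ccc(N(C)C)cc1` gives 2.3% in this assay

Of these two numbers, compound 2 has the lower one, yet the step of a number 2 percentage points lower from compound 1 to compound 2 (within the scatter) is within the scatter, so the two compounds cannot be told apart on this read-out, and both sit near the bottom of the percentage scale.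

Compound 3 `CN(C)c1ccc(C2CC(c3ccc(-n4ccnc4)cc3)=NN2C(=O)c2ccc(F)cc2)cc1` is the next compound. It differs from compound 2 by 4-fluorophenyl in place of (methoxycarbonyl)methyl on a carbonyl carbon. Within the data shown here, the one measured step, a number 2 percentage points lower from compound 1 to compound 2 (within the scatter), exchanged one small group for another at this same carbonyl carbon and gave no change beyond the scatter. Among the measured compounds shown here, no measured step brings an aromatic ring into this place, so there is nothing to point to a large move. Compound 3 is therefore expected to stay close to compound 2, with a step of a number 3.7 percentage points higher from compound 2 to compound 3 (within the scatter) estimated. The estimate for compound 3 is 6%, within a range from -6% to 22%.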

Compound 3, a percentage reported as inhibition, at one concentration (the size of the read-out at that concentration, not a potency): 9.4%
Estimate against measurement, compound 3: 3.4 percentage points below; the range from low to high includes it.
By their numbers in this assay, from the lowest: compounds 2, 1 and 3 (each within the scatter of the next).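

Compound 3 is the first of these compounds to carry an aromatic ring on this carbonyl carbon, and even this larger exchange gives a number 7.1 percentage points higher from compound 2 to compound 3 (within the scatter) in this assay, and a number 5.1 percentage points higher from compound 1 to compound 3 (within the scatter). On this read-out, then, 4-fluorophenyl cannot be told apart from either (methoxycarbonyl)methyl or 1-methylethenyl at this place, and all three compounds stay near the bottom of the percentage scale. Nothing at hand bears on what lies behind this result.

Going by these compounds, whether an amine, a carboxylic acid or a longer chain on this carbonyl carbon would move the number beyond the scatter remains open. Also open, on these data alone, is whether a change elsewhere on the shared core would do so, as these three compounds differ only in this one group.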